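The source may report more compounds than this note shows. Statements on the series, on what has been measured and on what is new or still open speak of the compounds shown alone.

In a functional assay on A549 cells (Homo sapiens) for inhibition, read by MTT assay, with a stated time of 72 h (a higher number here means a weaker inhibitor, a lower number a stronger inhibitor), two compounds have been measured so far:

Compound 1, `COc1cc2c(Oc3ccc(NC(=O)c4nn(-c5ccccc5C(F)(F)F)c(=O)cc4C)cc3F)ccnc2cc1OCCCN1CCCC1`: 130 nM
Compound 2, `COc1cc2c(Oc3ccc(NC(=O)c4nn(-c5ccccc5OC(F)(F)F)c(=O)cc4C)cc3F)ccnc2cc1OCCCN1CCCC1`: 140 nM

Within the data shown here, compound 2 gives the higher of the two numbers, but the only other value, that of compound 1, sits so close that the two cannot be told apart: the single measured step, a 1.1-fold higher number from compound 1 to compound 2 (0.03 log units; within the scatter), lies within the scatter. The next compound, compound 3, `COc1cc2c(Oc3ccc(NC(=O)c4nn(-c5ccccc5OC(F)(F)F)c(=O)cc4C)cc3F)ccnc2cc1OCCCN1CCN(C)CC1`, keeps everything in compound 2 except the amine at the end of the chain: 4-methylpiperazin-1-yl in place of pyrrolidin-1-yl on a saturated chain carbon, three bonds along the chain from an oxygen on an aromatic ring.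

Among the measured compounds shown here, no measured step touches this chain end; the one known step concerns the substituent on the aromatic ring at the other end of the molecule and was itself within the scatter. There is therefore nothing in the data that points to a shift in either direction in this assay for compound 3, and the expectation is a number close to that of compound 2. The expected step is no change at the digits printed from compound 2 to compound 3 (within the scatter), a change not beyond the scatter. Compound 3 is thus estimated at 140 nM, with a range from 60 nM to 330 nM.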

Compound 3, half-maximal inhibitory concentration: 130 nM
The estimate for compound 3 lay 1.1-fold (0.03 log units) above the measured number; the range from low to high includes it.
By their numbers in this assay, from the lowest: compounds 1, 3 and 2 (each within the scatter of the next).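

Among these compounds, the chain end had not been touched by the earlier step, which concerned only the substituent on the aromatic ring, so this is the first reading at this position. In this assay, replacing 3-(pyrrolidin-1-yl)propyl with 3-(4-methylpiperazin-1-yl)propyl exchanges a five-membered non-aromatic ring with 1 hetero atom for a six-membered one with 2 hetero atoms, yet it gives a 1.1-fold lower number from compound 2 to compound 3 (0.03 log units; within the scatter), so the assay does not separate these two amines at this place. No measurement is at hand that would explain this outcome, whether on the compounds' properties or on anything else beyond the cell read-out.

The compounds shown leave open whether this insensitivity extends to other groups at the chain end, such as morpholin-4-yl, dimethylamino, a primary amine or a carboxylic acid, or to a shorter or longer chain than propyl. They also leave open whether 4-methylpiperazin-1-yl would give a similar number when paired with the trifluoromethyl group in place of trifluoromethoxy, since the two changes are seen here only one at a time.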